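This account rests on a few compounds, and the source may have more. Where it says the series, first, only, none or still open, it means among the compounds named here.

Compounds measured in a toxicity assay on L02 cells (Homo sapiens) for cytotoxicity, read by MTT assay, with a stated time of 72 h; on this read-out higher numbers stand for weaker inhibition and lower numbers for stronger inhibition:
- compound 1 `O=C1c2c[n+]([O-])c3ccccc3c2C(=O)c2c1c1ccccc1n2Cc1cn([C@@H]2C[C@H](O)[C@@H](CO)O2)nn1`: 630 nM
- compound 2 `CC1(C)OCC(Cn2cc(Cn3c4c(c5ccccc53)C(=O)c3c[n+]([O-])c5ccccc5c3C4=O)nn2)O1`: 120 nM
- compound 3 `CN1CCN(CCCn2c3c(c4ccccc42)C(=O)c2c[n+]([O-])c4ccccc4c2C3=O)CC1`: 230 nM

Among these three, compound 2 gives the lowest number in this assay. Compound 3 lies close to it, and their two values sit within the usual scatter, so no order between them is claimed. Within the data shown here, compound 1 stands further off: the step of a 5.3-fold lower number from compound 1 to compound 2 (0.72 log units; beyond the scatter) is the only single-point change recorded here, and it is beyond the scatter.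

Compound 4 `O=C1c2c[n+]([O-])c3ccccc3c2C(=O)c2c1c1ccccc1n2Cc1cn(C[C@@H](O)CO)nn1` is not yet measured. It differs from compound 2 in one place: 1,2-dihydroxyethyl in place of 2,2-dimethyl-1,3-dioxolan-4-yl on a saturated chain carbon bound to an aromatic nitrogen. This change bears on the step from compound 1 to compound 2 in a partial way, since compound 1 also carries two hydroxyl groups and gave the higher number, while compound 2 carries the ring-closed dioxolane and gave the lower one. On that basis a higher number is expected for compound 4 in this assay, though smaller than the full return to compound 1, since the change from compound 2 is a smaller one; the estimated step is a 2.7-fold higher number from compound 2 to compound 4 (0.43 log units; beyond the scatter). Compound 4 is therefore estimated at 320 nM, with a range from 140 nM to 800 nM.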

Compound 4, half-maximal inhibitory concentration: 490 nM
Compound 4: middle estimate off by 1.5-fold (0.19 log units), on the low side; measured number inside the range.
By their numbers in this assay, from the lowest: compounds 2 and 3 (each within the scatter of the next); then compounds 4 and 1 (each within the scatter of the next).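

In this assay, putting 1,2-dihydroxyethyl in place of 2,2-dimethyl-1,3-dioxolan-4-yl on this saturated chain carbon is a step beyond the scatter (a 4.1-fold higher number from compound 2 to compound 4 (0.61 log units; beyond the scatter)), so the closed dioxolane and the free diol are not interchangeable here. The 2,3-dihydroxypropyl group of compound 4 and the 4-hydroxy-5-(hydroxymethyl)oxolan-2-yl group of compound 1 stay within the scatter (a 1.3-fold lower number from compound 1 to compound 4 (0.11 log units; within the scatter)), so these two hydroxyl-bearing groups are not told apart, and both stand apart from the dioxolane of compound 2. Compound 4 also stands beyond the scatter from the 2-(4-methylpiperazin-1-yl)ethyl compound (a 2.1-fold higher number from compound 3 to compound 4 (0.33 log units; beyond the scatter)).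

The compounds shown leave open how a carboxylic acid, a primary amine or a longer alkyl chain would read at this place. No measurement at hand gives a reason for these steps.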